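Replacing 2,6-difluorophenyl with (pyridin-4-yl)methyl on an amide-type nitrogen

This account rests on a few compounds, and the source may have more. Where it says the series, first, only, none or still open, it means among the compounds named here.

Of the compounds shown here, three sharing one core have been read in a physicochemical assay for lipophilicity, at pH 7.4; on this read-out higher numbers stand for higher lipophilicity and lower numbers for lower lipophilicity: compound 1 (`Cc1cc(C(=O)NC(C)C)nn1Cc1cc(Cl)ccc1OCc1ccccc1`), compound 2 (`Cc1cc(C(=O)Nc2ccccc2)nn1Cc1cc(Cl)ccc1OCc1ccccc1`) and compound 3 (`Cc1cc(C(=O)Nc2c(F)cccc2F)nn1Cc1cc(Cl)ccc1OCc1ccccc1`). Compound 1 gives > 3.7, which is a limit of the assay and not a number. Compound 2 gives > 3.7, which is likewise a limit. Among the measured compounds shown here, compound 3 gives 3.7, the only true number among the three.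

The next compound, compound 4 (`Cc1cc(C(=O)NCc2ccncc2)nn1Cc1cc(Cl)ccc1OCc1ccccc1`), has not yet been measured. The change leading to it is (pyridin-4-yl)methyl in place of 2,6-difluorophenyl on an amide-type nitrogen. For the measured compounds named here, three measured steps concern that same place: a step that the two limits leave unreadable from compound 1 to compound 2, then a number no higher from compound 1 to compound 3 (the limit leaves the size open), and finally a number no higher from compound 2 to compound 3 (the limit leaves the size open). None of them has a readable size, so they set no scale for the new change. Going by the values given here, no measured compound carries a hydrogen-bond acceptor or a hetero atom in the group at that place.

The expectation therefore rests on the structural change and on compound 3 at 3.7, and it points to a lower reading. The expected step, beyond the scatter, is a number 0.80 log units lower from compound 3 to compound 4 (beyond the scatter). For compound 4 the estimated value is 2.9, within an expected range from 2.4 to 3.4.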

Compound 4, distribution coefficient: > 3.7
Compound 4: a limit, no number; the forecaster's own chance of this, stated with the estimate: 5%; middle value at least 0.80 log units from the limit.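

In this assay, placing (pyridin-4-yl)methyl on the amide-type nitrogen gives a number no lower from compound 3 to compound 4 (the limit leaves the size open), so the first group shown at this place with a ring hetero atom and a hydrogen-bond acceptor does not bring the reading down from that of the 2,6-difluorophenyl amide. The result for compound 4 is a limit of the assay and not a number, so this step gives a direction only and no size. The steps to compound 4 from compound 1 and compound 2 cannot be read, and the series gives a number only for compound 3, the other compounds resting at one edge of this assay: the limit of > 3.7 in this assay, at which 3 of the 4 values shown sit.

Going by these compounds, how far compound 1, compound 2 and compound 4 lie past that limit remains open, and with it any ranking among the isopropyl, phenyl and (pyridin-4-yl)methyl amides. Also open, on these data alone, is whether an amine or a carboxylic acid at this place on the amide-type nitrogen would bring the reading to a true number that could set a scale for changes here.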